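Swapping methyl for bromo on the aryl ring of compound 2

The compounds below may be only part of what the source reports. "The series", "measured", "known", "first", "only" and "open" are said of these compounds alone.

Measured compounds:
- compound 1, `C#CCSc1nc(Sc2nc3ccccc3s2)c(C#N)c(-c2cc(OC)c(OC)c(OC)c2)n1`: > 20000 nM
- compound 2, `C#CCSc1nc(Sc2nccs2)c(C#N)c(-c2ccc(C)cc2)n1`: 1110 nM

Of the compounds shown here, two have been tested in a functional assay on PC-9 cells (Homo sapiens) for antiproliferative activity, read by MTT assay; a higher number here means a weaker inhibitor, a lower number a stronger inhibitor. Compound 1, with the structure `C#CCSc1nc(Sc2nc3ccccc3s2)c(C#N)c(-c2cc(OC)c(OC)c(OC)c2)n1`, reaches only a limit of the assay, > 20000 nM, so no number is known for it (the limit of > 20000 nM in this assay, at which 1 of the 2 values shown sits). Compound 2, with the structure `C#CCSc1nc(Sc2nccs2)c(C#N)c(-c2ccc(C)cc2)n1`, gives 1110 nM. Among the values shown, compound 2 therefore stands as the only compound with an actual number; the other value is a limit and cannot be ranked against it.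

Compound 3, `C#CCSc1nc(Sc2nccs2)c(C#N)c(-c2ccc(Br)cc2)n1`, has not yet been measured. It differs from compound 2 in one place (bromo in place of methyl on an aromatic carbon). Within the data shown here, no measured pair of compounds shows what such a change does within this set, so there is no step to lean on. Because compound 2 gives 1110 nM, the expectation for compound 3 is a value near it, with a step of a 1.1-fold lower number from compound 2 to compound 3 (0.05 log units; within the scatter), which is not expected to lie beyond the usual scatter. Compound 3 is thus estimated at 1000 nM, with a range from 300 nM to 3500 nM.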

Compound 3, half-maximal inhibitory concentration: 12100 nM
Estimate against measurement, compound 3: 12-fold (1.08 log units) below, and the stated range ends below it.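

In this assay, among these compounds, the exchange of 4-methylphenyl for 4-bromophenyl brings an 11-fold higher number from compound 2 to compound 3 (1.04 log units; beyond the scatter), the first comparison here in which only one place differs. Only one heavy atom is exchanged, and the counts of hydrogen-bond donors and acceptors and the net charge stay the same, so this aromatic carbon, para to a large group, is a place where the result in these cells responds strongly to a very small structural edit. Nothing shown gives a reason for the size of this step.

The compounds shown leave open whether methyl helps, bromo hurts, or both, and a plain hydrogen, a chloro, a methoxy or an amine at this place would show where the two groups lie on a wider scale. Also open, from the compounds shown here alone, is whether the step would keep its size with a different group on the rest of the shared core, for this single pair is the only one that speaks to the change.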